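Swapping an iodinated aryl group for a nitrile-bearing one

This account rests on a few compounds, and the source may have more. Where it says the series, first, only, none or still open, it means among the compounds named here.

Measured so far:
- compound 1, `COC(=O)C1=C(C)N=C(C)/C(=C(/O)OC)C1c1c(F)cccc1Cl`: 7.59 nM
- compound 2, `COC(=O)C1=C(C)N=C(C)/C(=C(\O)OC)C1c1ccccc1I`: 46.8 nM
- compound 3, `COC(=O)C1=C(C)N=C(C)/C(=C(\O)OC)C1c1c(F)c(F)c(F)c(F)c1F`: 4.37 nM

These values come from a functional assay (muscle tissue) with Cavia porcellus as the target; a higher number here means that more compound is needed for the effect, a lower number that less compound is needed. Compound 2 stands at the highest number of the three, and both compound 1 and compound 3 lie beyond the scatter from it, so compound 2 needs the most compound for the effect.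

Compound 4, `COC(=O)C1=C(C)N=C(C)/C(=C(\O)OC)C1c1cccc(C#N)c1`, has not yet been measured. It differs from compound 2 in one place: 3-cyanophenyl in place of 2-iodophenyl on a saturated ring carbon. The entering group carries one triple bond outside aromatic rings and one hydrogen-bond acceptor, which the leaving group lacks.

Among the compounds with values here, no measured pair shows this change, so the expectation rests on the spread alone. The step is expected to be a 2.3-fold lower number from compound 2 to compound 4 (0.37 log units; beyond the scatter), a move toward the lower numbers. Compound 4 is expected to give 20 nM, somewhere between 4 nM and 100 nM.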

Compound 4, half-maximal effective concentration: 34.7 nM
Estimate against measurement, compound 4: 1.7-fold (0.24 log units) below; measured number inside the range.
By their numbers in this assay, from the lowest: compounds 3 and 1 (each within the scatter of the next); then compounds 4 and 2 (each within the scatter of the next).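

In this assay the swap gives a 1.3-fold lower number from compound 2 to compound 4 (0.13 log units; within the scatter) and stays within the scatter, so 3-cyanophenyl and 2-iodophenyl cannot be told apart at this saturated ring carbon. The change replaces the iodine with a nitrile and also moves the substituent on the aromatic ring, yet no difference can be read. No available evidence explains this result.

Which of those two changes matters, if either, stays open. So does the outcome with an amine or a carboxylic acid on the aromatic ring.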